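The source may report more compounds than this note shows. Statements on the series, on what has been measured and on what is new or still open speak of the compounds shown alone.

Compound 1 `Cc1ccccc1S(=O)(=O)Nc1ccc2oc(-c3ccccc3)nc2c1` is one of three measured compounds. In an assay on isolated protein for inhibition of malate dehydrogenase, mitochondrial (Sus scrofa), with stated times of 45 min and 30 min (on this read-out higher numbers stand for weaker inhibition and lower numbers for stronger inhibition), compound 1 gives > 63000 nM, which is a limit of the assay rather than a number. Compound 2 `O=S(=O)(Nc1ccc(-c2nc3ccccc3o2)cc1)c1ccccc1F` gives > 63000 nM in this assay, again a limit. Compound 3 `O=S(=O)(Nc1ccc(-c2nc3ccccc3o2)cc1)c1ccccc1O` gives > 63000 nM in this assay, also a limit. Among the measured compounds shown here, compound 1 therefore stands at the limit, where every value so far sits (the limit of > 63000 nM in this assay, at which 3 of the 3 values shown sit).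

Compound 4 `O=S(=O)(Nc1ccc2oc(-c3ccccc3)nc2c1)c1ccccc1O` differs from compound 1 by hydroxy in place of methyl on an aromatic carbon. For the measured compounds named here, the only measured step that bears on a hydroxy entering an aromatic ring is a step that the two limits leave unreadable from compound 2 to compound 3, whose size cannot be read because both of its ends rest at the limit (the limit of > 63000 nM in this assay, at which 3 of the 3 values shown sit). Going by the values given here, no measured step shows a change that brings a value below the limit, so nothing points to a step beyond the scatter. The step from compound 1 to compound 4 is estimated at a step that the limit leaves unreadable from compound 1 to compound 4. Compound 4 is thus expected to give 100000 nM in this assay, within 40000 nM to 300000 nM, and most likely to be reported only as a limit.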

Compound 4, half-maximal inhibitory concentration: > 63000 nM
Compound 4: no number, only a limit; the forecaster's own chance of this, stated with the estimate: 85%; the middle value lies beyond the limit too.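

Compound 1 and compound 4 both rest at a limit and give no number, so no new step can be read between them: the limit of > 63000 nM in this assay, at which 4 of the 4 values shown sit. The compounds shown leave open how large the change from methyl to hydroxy is in this assay, and what would bring a value within the measurable range.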